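The source may report more compounds than this note shows. Statements on the series, on what has been measured and on what is new or still open speak of the compounds shown alone.

Working notes on the sulfonamide series. In a functional assay on MCF7 cells (Homo sapiens) for antiproliferative activity, read by sulforhodamine B assay, with a stated time of 48 h (a lower number here means a stronger inhibitor, a higher number a weaker inhibitor), compound 1, `O=C1NCCN1c1ccc(S(=O)(=O)Nc2ccc(OC(F)F)cc2)cc1`, gives 760 nM, and compound 3, `COc1ccccc1NS(=O)(=O)c1ccc(N2CCNC2=O)cc1`, gives 770 nM; these two numbers lie within the scatter of each other, so no order between them is claimed. Compound 2, `CC(C)Cc1ccc(NS(=O)(=O)c2ccc(N3CCNC3=O)cc2)cc1`, returns only a limit in this assay, > 1000 nM. For the measured compounds named here, the one measured step, an at least 1.3-fold higher number from compound 1 to compound 2 (0.11 log units; that floor lies within the scatter), is bounded by the limit of > 1000 nM in this assay, at which 1 of the 3 values shown sits, so its true size is unknown beyond that floor.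

Compound 4, `O=C1NCCN1c1ccc(S(=O)(=O)Nc2cccc(Cl)c2)cc1`, differs from compound 3 by 3-chlorophenyl in place of 2-methoxyphenyl on a sulfonamide nitrogen. Going by the values given here, no measured step exchanges the whole aryl group on the sulfonamide nitrogen; the step from compound 1 to compound 2 changes only a substituent on that ring and gives no clear read on a chloro-for-methoxy swap at a different place. The expectation for compound 4 is therefore a step of a 1.0-fold higher number from compound 3 to compound 4 (0.02 log units; within the scatter), in no direction beyond the scatter. Compound 4 is estimated at 800 nM, expected to fall between 350 nM and 1900 nM.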

Compound 4, half-maximal inhibitory concentration: 79 nM
Compound 4: the middle estimate sits 10-fold (1.01 log units) above what was measured; the whole stated range lies above it.
By their numbers in this assay, from the lowest: compound 4; then compounds 1 and 3 (each within the scatter of the next). At a limit, above all of these: compound 2.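

In this assay, for the compounds shown here, the group on the sulfonamide nitrogen can shift the number well beyond the scatter: a 9.7-fold lower number from compound 3 to compound 4 (0.99 log units; beyond the scatter), whereas the one earlier step had only a floor lying within the scatter. This single exchange of 2-methoxyphenyl for 3-chlorophenyl changes both the substituent and its place on the ring, so it cannot show which of the two carries the step. No measurement given here bears on the origin of this step.

Going by these compounds, whether chlorine itself matters, or only its place on the ring, remains open. Also open, on these data alone, is how an unsubstituted phenyl, a bromophenyl or an aminophenyl on the sulfonamide nitrogen would stand against compound 4 in this assay.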